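Methoxy to hydrogen on an anticonvulsant succinimide series

The source may hold more compounds than are shown below. What is called first, only, known or untested is meant among the compounds shown, and "the series" means these compounds.

Measured compounds:
Compound 1, `COCC(C(=O)N1CCN(c2cccc(C(F)(F)F)c2)CC1)N1C(=O)CCC1=O`: 0%
Compound 2, `CCC(C(=O)N1CCN(c2ccccc2)CC1)N1C(=O)CCC1=O`: 0%

Of the compounds shown here, two have been tested in a functional assay on the whole organism (strain Swiss) with Mus musculus as the target, in the maximal electroshock model, with a stated time of 2 h, at a dose of 100 mg/kg by the intraperitoneal route; on this read-out lower numbers stand for a weaker effect and higher numbers for a stronger effect at the one dose given. Compound 1, `COCC(C(=O)N1CCN(c2cccc(C(F)(F)F)c2)CC1)N1C(=O)CCC1=O`, gives 0% in this assay. Compound 2, `CCC(C(=O)N1CCN(c2ccccc2)CC1)N1C(=O)CCC1=O`, likewise gives 0% in this assay. Compound 1 therefore stands level with compound 2 at the digits shown; the two values lie within the usual scatter of each other, and no order can be read between them. Among the compounds with values here, no step between a pair of measured compounds differing in one place is available.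

The unmeasured compound 3, `CC(C(=O)N1CCN(c2cccc(C(F)(F)F)c2)CC1)N1C(=O)CCC1=O`, differs from compound 1 by hydrogen in place of methoxy on a saturated chain carbon, two bonds along the chain from an amide-type nitrogen in a ring and a carbonyl carbon. Both measured compounds sit at the bottom of the scale in this assay, and the shared core with its phenylpiperazine amide and succinimide ring is kept in compound 3. On this basis no change beyond the scatter is expected from compound 1 to compound 3 in this assay, with a step of no change at the digits printed from compound 1 to compound 3 (within the scatter). Compound 3 is accordingly estimated at 0% in this assay, in a range from 0% to 20%.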

Compound 3, a percentage reported as activity, at one dose (the size of the read-out at that dose, not a potency): 0%
Compound 3: middle estimate and measured number agree at the digits printed; the measured number falls inside the stated range.
By their numbers in this assay, from the lowest: compounds 1, 2 and 3 (each within the scatter of the next).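

In this assay, within the data shown here, the one step now available that changes a single place reads no change at the digits printed from compound 1 to compound 3 (within the scatter), with hydrogen in place of methoxy on a saturated chain carbon, two bonds along the chain from an amide-type nitrogen in a ring and a carbonyl carbon. This shows that cutting methoxymethyl back to methyl at this position, with the rest of the compound kept, does not lift the read-out off the bottom of the scale at the one dose given; it does not show that the methoxy group is without consequence, for a step that starts at the bottom of the scale cannot reveal a loss. Nothing at hand bears on why the read-out stays there.

The compounds shown leave open whether a hydroxyl, a primary amine or a benzyl group on this chain carbon would give a read-out above the bottom of the scale. They also leave open what the exchange of methoxy for hydrogen does in a compound of this series with a measurable effect, where a loss or a gain could be seen.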